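A few compounds are considered here, and "the series" means these few. Any claim that something is new, unique, unknown or untested is made for them only; others in the source may bear on it.

Working notes on the series. Compound 1 `CC(C)(C)c1cn(Cc2cc(=O)oc3cc(O)ccc23)nn1` carries tert-butyl on the shared core; compound 2 `O=c1cc(Cn2cc(CCc3ccccc3)nn2)c2ccc(O)cc2o1` carries phenethyl at the same place. In a functional assay on CFPAC-1 cells (Homo sapiens) for inhibition, read by MTT assay, with a stated time of 72 h (a higher number here means a weaker inhibitor, a lower number a stronger inhibitor), compound 1 gives only a limit of the assay, > 100000 nM. In this assay compound 2 likewise gives only a limit of the assay, > 100000 nM. The step that the two limits leave unreadable from compound 1 to compound 2 is therefore unreadable, both values being (the limit of > 100000 nM in this assay, at which 2 of the 2 values shown sit). Compound 3 `O=c1cc(Cn2cc(-c3cc(F)cc(F)c3)nn2)c2ccc(O)cc2o1` differs from compound 2 by 3,5-difluorophenyl in place of phenethyl on an aromatic carbon. For the measured compounds named here, no measured step sets a size for this change, so no shift beyond the scatter is expected, and compound 3 is expected to stay near the limit, estimated at 120000 nM with a range of 30000 nM to 500000 nM, a step that the limit leaves unreadable from compound 2 to compound 3.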

Compound 3, half-maximal inhibitory concentration: > 100000 nM
Compound 3 gave a limit, no number; the forecaster's own chance of this, stated with the estimate: 75%; the middle value lies beyond the limit too.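

In this assay, for the compounds shown here, compound 3 gives only a limit, as do compound 1 and compound 2, and no step among the three can be read: the limit of > 100000 nM in this assay, at which 3 of the 3 values shown sit. The compounds shown leave open whether any group at this place on the shared core gives a measurable value.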